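A few compounds are considered here, and "the series" means these few. Any claim that something is new, unique, unknown or untested is made for them only; others in the source may bear on it.

Values measured in a functional assay on HepG2 cells (Homo sapiens) for antiproliferative activity, read by MTT assay (on this read-out lower numbers stand for stronger inhibition and higher numbers for weaker inhibition), are these
Compound 1 `CC(=O)c1ccc(-n2cc(COc3ccc(/C=C/C(=O)c4cc5c(cc4O)OC(C)(C)CC5)cc3)nn2)cc1` gives "not active" (no number reported)
Compound 2 `Cc1ccc(-n2cc(COc3ccc(/C=C/C(=O)c4cc5c(cc4O)OC(C)(C)CC5)cc3)nn2)cc1Br` gives 117000 nM
Compound 3 `CC1(C)CCc2c(ccc(C(=O)/C=C/c3ccc(OCc4cn(-c5ccc(Br)cc5)nn4)cc3)c2O)O1` gives 136000 nM

Compound 2 at 117000 nM and compound 3 at 136000 nM lie within the usual scatter of each other. Going by the values given here, compound 3 therefore stands level with the only other number, while compound 1 gave no number.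

Compound 4 `CCc1ccccc1-n1cc(COc2ccc(/C=C/C(=O)c3ccc4c(c3O)CCC(C)(C)O4)cc2)nn1` keeps the core of compound 3 and carries 2-ethylphenyl in place of 4-bromophenyl on an aromatic nitrogen of a five-membered aromatic ring with 3 nitrogen (2-ethylphenyl in place of 4-bromophenyl on an aromatic nitrogen). Among the compounds with values here, no two measured compounds differ in one place only, so the data give no direct size for this change. In this assay no step beyond the scatter is expected, in either direction, taking compound 3 at 136000 nM as the anchor. Compound 1, reported as "not active" (no number reported), shows that a result without a number also remains possible. The expected change is a 1.4-fold lower number from compound 3 to compound 4 (0.13 log units; within the scatter). For compound 4 the estimated value is 100000 nM, with an expected range from 35000 nM to 250000 nM.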

Compound 4, half-maximal inhibitory concentration: 67800 nM
For compound 4 the middle estimate is 1.5-fold (0.17 log units) above the measured one; low and high end bracket the measured number.
By their numbers in this assay, from the lowest: compounds 4, 2 and 3 (each within the scatter of the next).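

In this assay, going by these compounds alone, putting 2-ethylphenyl in place of 4-bromophenyl on the aromatic nitrogen gives a 2.0-fold lower number from compound 3 to compound 4 (0.30 log units; within the scatter), the first step in this set between compounds that differ in one place. At this position, then, the bromine of 4-bromophenyl can be exchanged for the ethyl group of 2-ethylphenyl, with the substituent also moved around the ring, without a step beyond the scatter, and the compound still gives a number. No measurement at hand bears on why this exchange leaves the number within the scatter.

From the compounds shown here alone, whether an unsubstituted phenyl, or a phenyl carrying an amine or a carboxylic acid, would also stay within the scatter at this nitrogen remains open. Going by these compounds, it also remains open how 2-ethylphenyl would behave on the core of compound 2.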